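The compounds below may be only part of what the source reports. "The series", "measured", "known", "first", "only" and "open" are said of these compounds alone.

Measured compounds in a functional assay on HepG2 cells (Homo sapiens) for inhibition, read by MTT assay, with a stated time of 48 h; a lower number here means a stronger inhibitor, a higher number a weaker inhibitor:
compound 1 `COc1ccc(-n2c(SCc3ccc(F)cc3)nnc2-c2cc(OC)c(OC)c(OC)c2)cc1` gives 35000 nM.
compound 2 `COc1ccc(-n2c(SCC(=O)C3CC3)nnc2-c2cc(OC)c(OC)c(OC)c2)cc1` gives only a limit, > 60000 nM.
compound 3 `COc1cc(-c2nnc(S)n2-c2ccc(N(C)C)cc2)cc(OC)c1OC` gives only a limit, > 60000 nM.

Compound 3 therefore stands at the limit of > 60000 nM in this assay, at which 2 of the 3 values shown sit; no number is known for it, and compound 2 sits at the same limit. For the measured compounds named here, compound 1 is the only member of the series with a number in this assay.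

Compound 4 `COc1cc(-c2nnc(SCC(=O)c3ccc(F)cc3)n2-c2ccc(N(C)C)cc2)cc(OC)c1OC` differs from compound 3 in one place: ((4-fluorophenyl)carbonyl)methyl in place of hydrogen on a sulfur. Going by the values given here, the only measured step, an at least 1.7-fold higher number from compound 1 to compound 2 (0.23 log units; that floor lies within the scatter), concerns an exchange on the chain carbon bound to the sulfur and not the change from a bare sulfanyl group to a substituted one; it shows merely that both substituted thioethers of that pair lie at weak potency in this assay. Among the compounds with values here, no measured step bears directly on the change from compound 3 to compound 4, so the direction of the step is not fixed by the data, and weak potency is expected either way. Compound 4 is estimated at 45000 nM, with a range from 15000 nM to 100000 nM. That estimate corresponds to an expected step of an at least 1.3-fold lower number from compound 3 to compound 4 (0.12 log units; that floor lies within the scatter), with a fair chance that this assay again returns only a limit.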

Compound 4, half-maximal inhibitory concentration: > 60000 nM
Compound 4 gave a limit, no number; the forecaster's own chance of this, stated with the estimate: 50%; middle value at least 1.3-fold (0.12 log units) from the limit.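

Compound 3 and compound 4 both return only a limit in this assay, so no step between them can be read: the limit of > 60000 nM in this assay, at which 3 of the 4 values shown sit.

The compounds shown leave open whether ((4-fluorophenyl)carbonyl)methyl in place of hydrogen on a sulfur moves the number in either direction.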